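A few compounds are considered here, and "the series" means these few. Any claim that something is new, unique, unknown or untested is made for them only; others in the source may bear on it.

Measured so far in a functional assay on SK-HEP1 cells (Homo sapiens) for cytotoxicity, read by sulforhodamine B assay, with a stated time of 72 h; on this read-out lower numbers stand for stronger inhibition and higher numbers for weaker inhibition: compound 1 `CCS(=O)(=O)Nc1cc(-c2ccc3ncnc(Nc4ccc(F)cc4)c3c2)cnc1OC` at 1470 nM; compound 2 `CCS(=O)(=O)Nc1cc(-c2ccc3ncnc(Nc4ccc(F)cc4F)c3c2)cnc1OC` at 2490 nM.

Within the data shown here, compound 2 and compound 1 sit within the scatter of each other, the only measured step being a 1.7-fold higher number from compound 1 to compound 2 (0.23 log units; within the scatter). Compound 3 `CCS(=O)(=O)Nc1cc(-c2ccc3ncnc(Nc4ccc(OC(F)(F)F)cc4)c3c2)cnc1OC` is not yet measured. Its change from compound 2 is 4-(trifluoromethoxy)phenyl in place of 2,4-difluorophenyl on a nitrogen on an aromatic ring. Among the measured compounds shown here, no measured step covers a group of this kind; the one step known, a 1.7-fold higher number from compound 1 to compound 2 (0.23 log units; within the scatter), was within the scatter, so no step beyond the scatter in this assay is expected for a 1.2-fold lower number from compound 2 to compound 3 (0.10 log units; within the scatter). Compound 3 is therefore estimated at 2000 nM, between 800 nM and 5000 nM.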

Compound 3, half-maximal inhibitory concentration: 6140 nM
For compound 3 the middle estimate is 3.1-fold (0.49 log units) below the measured one; the whole stated range lies below it.
By their numbers in this assay, from the lowest: compounds 1 and 2 (each within the scatter of the next); then compound 3.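

The aryl group on a nitrogen on an aromatic ring now gives steps beyond the scatter in this assay: a 2.5-fold higher number from compound 2 to compound 3 (0.39 log units; beyond the scatter) and a 4.2-fold higher number from compound 1 to compound 3 (0.62 log units; beyond the scatter), both modest. Among the three compounds, only the change to trifluoromethoxy moves the number beyond the scatter, whereas the added fluoro did not. Nothing at hand accounts for this shift.

Open, as far as these compounds go, is whether methoxy, trifluoromethyl or a dimethylamino group in place of trifluoromethoxy would stay with compound 1 or move with compound 3. The shared core stays fixed, so changes elsewhere remain unread.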